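Replacing 4-(tert-butyl)phenyl with 3-bromophenyl in compound 2

This account rests on a few compounds, and the source may have more. Where it says the series, first, only, none or still open, it means among the compounds named here.

Compound 1 `O=C(COc1ccc(C(=O)/C=C/c2ccc(F)c(F)c2)cc1)N[C@H]1CCOC1=O`: > 64000 nM, a limit
Compound 2 `CC(C)(C)c1ccc(/C=C/C(=O)c2ccc(OCC(=O)N[C@H]3CCOC3=O)cc2)cc1`: 16400 nM

Among the measured compounds shown here, in a functional assay on MCF7 cells (Homo sapiens) for antiproliferative activity, read by MTT assay, with a stated time of 72 h (on this read-out higher numbers stand for weaker inhibition and lower numbers for stronger inhibition), compound 2 gives 16400 nM, the only actual number so far. Compound 3 `O=C(COc1ccc(C(=O)/C=C/c2cccc(Br)c2)cc1)N[C@H]1CCOC1=O` differs from it at one place: 3-bromophenyl in place of 4-(tert-butyl)phenyl on a double-bonded chain carbon bound to a double-bonded chain carbon. For the measured compounds named here, the one measured step at this place is an at least 3.9-fold lower number from compound 1 to compound 2 (0.59 log units; beyond the scatter), and there the 4-(tert-butyl)phenyl compound gave the stronger inhibition. Compound 3 also gives up that group, so weaker inhibition is expected. The expected change is a 1.8-fold higher number from compound 2 to compound 3 (0.26 log units; within the scatter). For compound 3 the estimate is 30000 nM, with an estimated range of 12000 nM to 64000 nM.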

Compound 3, half-maximal inhibitory concentration: 28300 nM
The estimate for compound 3 lay 1.1-fold (0.03 log units) above the measured number; measured number inside the range.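

In this assay the change brings a 1.7-fold higher number from compound 2 to compound 3 (0.24 log units; within the scatter), so 3-bromophenyl and 4-(tert-butyl)phenyl cannot be told apart at this place, although they differ in heavy atoms and in carrying bromine. Replacing 3,4-difluorophenyl brings an at least 2.2-fold lower number from compound 1 to compound 3 (0.35 log units; beyond the scatter), so the stronger inhibition seen earlier does not belong to 4-(tert-butyl)phenyl alone. Compound 1 remains a limit, not a number, and the steps from it have no fixed size: the limit of > 64000 nM in this assay, at which 1 of the 3 values shown sits.

The compounds shown leave open how 4-bromophenyl would compare with 3-bromophenyl here. They also leave open whether a phenyl ring carrying an amine or a carboxylic acid would keep this level of inhibition.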